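The source may report more compounds than this note shows. Statements on the series, on what has been measured and on what is new or still open speak of the compounds shown alone.

Measured so far:
- compound 1, `CCc1cccc(Nc2cc(NC(=O)Nc3cc(OC)cc(OC)c3)ncn2)c1`: 23%
- compound 2, `COc1cc(NC(=O)Nc2cc(Nc3ccc(Br)cc3OC)ncn2)cc(OC)c1`: 36.1%

In a functional assay on NCI-H520 cells (Homo sapiens) for inhibition, read by MTT assay, with a stated time of 48 h, tested at 10 uM (on this read-out higher numbers stand for more inhibition at the one concentration tested (going by the name of the read-out) and lower numbers for less inhibition), compound 2 gives 36.1% and stands highest of the two numbers; the nearest is compound 1, which gives 23%. Within the data shown here, the one step between them is a number 13.1 percentage points higher from compound 1 to compound 2 (beyond the scatter), and it is the only measured change at this nitrogen.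

Compound 3, `COc1cc(NC(=O)Nc2cc(Nc3ccc(C)c(C)c3)ncn2)cc(OC)c1`, is not yet measured. It differs from compound 2 at the same nitrogen: 3,4-dimethylphenyl in place of 4-bromo-2-methoxyphenyl on a nitrogen on an aromatic ring.

The measured step bears on this one only loosely, since it exchanged 3-ethylphenyl for 4-bromo-2-methoxyphenyl, while here 4-bromo-2-methoxyphenyl gives way to 3,4-dimethylphenyl. Compound 3 therefore returns to a ring that carries only carbon, as in compound 1, and a modest fall in this assay is expected, partly reversing a number 13.1 percentage points higher from compound 1 to compound 2 (beyond the scatter). For compound 3 the expected step is estimated as a number 9.1 percentage points lower from compound 2 to compound 3 (within the scatter). For compound 3 the estimate in this assay is 27%, within 12% to 42%.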

Compound 3, a percentage reported as inhibition, at one concentration (the size of the read-out at that concentration, not a potency): 29.5%
Compound 3: the middle estimate sits 2.5 percentage points below what was measured, within the range that was stated.
By their numbers in this assay, from the lowest: compounds 1, 3 and 2 (each within the scatter of the next, the first and the last beyond it).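

In this assay, among these compounds, the change on a nitrogen on an aromatic ring reads as a number 6.6 percentage points lower from compound 2 to compound 3 (within the scatter) and as a number 6.5 percentage points higher from compound 1 to compound 3 (within the scatter) in this series. 3,4-Dimethylphenyl therefore cannot be told apart from either 4-bromo-2-methoxyphenyl or 3-ethylphenyl, although the two latter groups are separated by the one step beyond the scatter. A group with only carbon on its ring thus does not form a clear separate class from 4-bromo-2-methoxyphenyl at this position, and no measured evidence accounts for any of these differences.

Open, from the compounds shown here alone, is whether a phenyl carrying a dimethylamino group or a carboxylic acid at this nitrogen would move the read-out clearly outside this narrow band. Also open, going by these compounds, is whether a longer alkyl chain on the phenyl would do so.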